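Halogen swap on a fused ring and microsomal stability

This account rests on a few compounds, and the source may have more. Where it says the series, first, only, none or still open, it means among the compounds named here.

Measured compounds:
compound 1, `CCn1c(=O)/c(=C2\Sc3cccc(F)c3N2C)s/c1=C\c1ccccn1`, 12%
compound 2, `CCn1c(=O)/c(=C2\Sc3cc(F)ccc3N2C)s/c1=C\c1ccccn1`, 5%
compound 3, `CCn1c(=O)/c(=C2\Sc3cccc(Cl)c3N2C)s/c1=C\c1ccccn1`, 38%

Three compounds were tested in an ADME assay on microsomes from liver (Mus musculus) for metabolic stability, with a stated time of 30 min; a higher number here means that more of the compound is left, a lower number that less of the compound is left. Compound 1 gives 12%, compound 2 gives 5%, and compound 3 gives 38%. Compound 1 and compound 2 share the same atoms joined differently; the difference between these two cores is not broken down here, and their values in this assay lie within the scatter of each other. Compound 3 differs from compound 1 by chloro in place of fluoro on an aromatic carbon, and this gave a number 26 percentage points higher from compound 1 to compound 3 (beyond the scatter).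

Compound 4, `CCn1c(=O)/c(=C2\Sc3cc(Cl)ccc3N2C)s/c1=C\c1ccccn1`, has not yet been measured. It differs from compound 2 by chloro in place of fluoro on an aromatic carbon. This is the same kind of change as from compound 1 to compound 3, but the place is not the same: in compound 4 the chloro sits meta to a fused ring and para to a fused ring, whereas in compound 3 it sits ortho to a fused ring and meta to a fused ring. Resting on compound 2 at 5% and on the earlier step of a number 26 percentage points higher from compound 1 to compound 3 (beyond the scatter), a step of a number 15 percentage points higher from compound 2 to compound 4 (beyond the scatter) is expected in this assay. Compound 4 is therefore estimated at 20%, between 6% and 40%.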

Compound 4, percent of the compound remaining: 13%
For compound 4 the middle estimate is 7 percentage points above the measured one; measured number inside the range.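

Chloro in place of fluoro on an aromatic carbon gave a number 8 percentage points higher from compound 2 to compound 4 (within the scatter) in this assay. Set beside the earlier step, the same change does not carry over with one size from one core to the other: the same change on two cores in this assay, a number 26 percentage points higher (beyond the scatter) from compound 1 to compound 3 and a number 8 percentage points higher (within the scatter) from compound 2 to compound 4, 18 percentage points apart, beyond the scatter of two such steps. This shows that the rise seen with the chloro group in compound 3 cannot be assumed for a chloro group sitting meta to a fused ring and para to a fused ring, but it does not show why the two steps differ, and two pairs set no rule for the series.

The compounds shown vary only the halogen and its place, so they leave open how the number would respond to a bromo group, a methoxy group or a nitrile on the same ring. They also leave open whether changes elsewhere on the shared core, such as an amine or a longer chain, would follow either step.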